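Swapping a Difluorophenyl for a Trifluoromethylphenyl

A few compounds are considered here, and "the series" means these few. Any claim that something is new, unique, unknown or untested is made for them only; others in the source may bear on it.

Of the compounds shown here, three built on one shared core have been tested in a functional assay on HepG2 cells (Homo sapiens) for inhibition, read by MTT assay, with a stated time of 72 h; on this read-out lower numbers stand for stronger inhibition and higher numbers for weaker inhibition. Compound 1 `CN(C(=O)NC(=O)c1c(F)cccc1F)c1nc(C(F)(F)F)c(C(=O)N/N=C/c2cccc(C(F)(F)F)c2)s1` gives 27.9 ug/mL. Compound 2 `CN(C(=O)NC(=O)c1cccc(C(F)(F)F)c1)c1nc(C(F)(F)F)c(C(=O)N/N=C/c2cc(C(F)(F)F)cc(C(F)(F)F)c2)s1` gives 5.38 ug/mL in this assay. Compound 3 `CN(C(=O)NC(=O)c1ccc(F)c(F)c1)c1nc(C(F)(F)F)c(C(=O)N/N=C/c2cccc(C(F)(F)F)c2)s1` gives 5.6 ug/mL in this assay. Compound 3 stands second highest of the three numbers: its value sits within the scatter of compound 2, while compound 1 is set apart from it by a 5.0-fold lower number from compound 1 to compound 3 (0.70 log units; beyond the scatter), a modest step.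

Compound 4 `CN(C(=O)NC(=O)c1cccc(C(F)(F)F)c1)c1nc(C(F)(F)F)c(C(=O)N/N=C/c2cccc(C(F)(F)F)c2)s1` differs from compound 3 in one place: 3-(trifluoromethyl)phenyl in place of 3,4-difluorophenyl on a carbonyl carbon. Among the measured compounds shown here, only one measured step touches that same carbonyl carbon, a 5.0-fold lower number from compound 1 to compound 3 (0.70 log units; beyond the scatter), which exchanged one difluorophenyl for another. Compound 2 carries the very group that enters here on the same carbonyl carbon, though with a different ring on the hydrazone side, and its value lies within the scatter of compound 3. For the measured compounds named here, no measured step shows directly how the entering group compares with the leaving one on an otherwise identical molecule. Compound 4 is therefore expected to show a 1.0-fold lower number from compound 3 to compound 4 (0.01 log units; within the scatter), a change not beyond the scatter. Compound 4 is thus estimated at 5.5 ug/mL, with a range from 2.5 ug/mL to 12 ug/mL.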

Compound 4, half-maximal inhibitory concentration: 5.79 ug/mL
Beside the measured number, compound 4's estimate is 1.1-fold (0.02 log units) below it, and the stated range covers the measured number.
By their numbers in this assay, from the lowest: compounds 2, 3 and 4 (each within the scatter of the next); then compound 1.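

Compound 3 and compound 4 differ only in the group on the carbonyl carbon, so they give the direct comparison that was missing: in this assay, the exchange of 3,4-difluorophenyl for 3-(trifluoromethyl)phenyl gives a 1.0-fold higher number from compound 3 to compound 4 (0.01 log units; within the scatter) and so does not separate the two groups, although the entering group has 10 heavy atoms and the leaving one has 8. At the same carbonyl carbon, 2,6-difluorophenyl now stands apart from two other groups, with a 5.0-fold lower number from compound 1 to compound 3 (0.70 log units; beyond the scatter) and also a 4.8-fold lower number from compound 1 to compound 4 (0.68 log units; beyond the scatter) on the same hydrazone side. On that hydrazone side, a separate change in one place gives a 1.1-fold higher number from compound 2 to compound 4 (0.03 log units; within the scatter), so the second trifluoromethyl on that ring does not shift the number beyond the scatter in this pair.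

Still open, going by these compounds, is whether a ring carrying an amine or a carboxylic acid, or a short alkyl chain in place of the ring, would keep the number near those of compound 3 and compound 4 when placed on this carbonyl carbon. Nothing available gives a measured reason for any of these steps.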